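This account rests on a few compounds, and the source may have more. Where it says the series, first, only, none or still open, it means among the compounds named here.

Measured in a functional assay on Jurkat cells (Homo sapiens) for cytotoxicity, read by luminescence and CellTiter-Glo, with a stated time of 3 days; on this read-out higher numbers stand for weaker inhibition and lower numbers for stronger inhibition:
Compound 1 `O=C(Nc1cc(C(F)(F)F)cc(C(F)(F)F)c1)c1ccc(Br)cc1O`: 930 nM
Compound 2 `N#Cc1ccc(NC(=O)c2cc(Br)c3cccnc3c2O)cc1`: 230 nM

Compound 2, at 230 nM, holds the lower of the two numbers, and the gap to compound 1 lies beyond the usual scatter. Compound 3 `N#Cc1ccc(NC(=O)c2ccc3cccnc3c2O)cc1` changes compound 2 in one place: hydrogen in place of bromo on an aromatic carbon. For the measured compounds named here, no measured pair shows this change, so the expectation is tentative: a modest move in this assay toward a higher number, that is, weaker inhibition. The expected step is a 2.0-fold higher number from compound 2 to compound 3 (0.29 log units; within the scatter). For compound 3 the estimated value is 450 nM, with an expected range of 130 nM to 1500 nM.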

Compound 3, half-maximal inhibitory concentration: 180 nM
For compound 3 the middle estimate is 2.5-fold (0.40 log units) above the measured one; the measured number falls inside the stated range.
By their numbers in this assay, from the lowest: compounds 3 and 2 (each within the scatter of the next); then compound 1.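

In this assay, hydrogen in place of bromo on the aromatic carbon para to a hydroxy group gives a 1.3-fold lower number from compound 2 to compound 3 (0.11 log units; within the scatter). The bromo at this position is therefore not required for a number of this size, and compound 2 and compound 3 cannot be told apart here. Nothing at hand offers an explanation for this result. The compounds shown leave open how an amine or a carboxylic acid on this same carbon would read in this assay. They also leave open whether replacing the hydroxy group with a methoxy group would matter more than this change did.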